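A few compounds are considered here, and "the series" means these few. Any claim that something is new, unique, unknown or untested is made for them only; others in the source may bear on it.

Working notes on the series.

Compound 1 `C=C1C[C@]23C[C@@]1(O)CC[C@H]2c1cc(Br)c(O)c(C)c1[C@@H]3Cn1cc(-c2ccc(OC)cc2)nn1` and compound 2 `C=C1C[C@]23C[C@@]1(O)CC[C@@H]2c1cccc(C)c1[C@@H]3Cn1cc(-c2ccccn2)nn1` share the same core and are both read in a functional assay on SMMC-7721 cells (Homo sapiens) for cytotoxicity, read by MTT assay, with a stated time of 4 days; a higher number here means a weaker inhibitor, a lower number a stronger inhibitor. Compound 1 gives only a limit in this assay, > 20000 nM. Compound 2 likewise gives only a limit in this assay, > 20000 nM. Within the data shown here, both values shown sit at the same place, as summarised by the limit of > 20000 nM in this assay, at which 2 of the 2 values shown sit, so no step between measured compounds can be sized, and where compound 2 stands is known only as a limit.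

Compound 3 `C=C1C[C@]23C[C@@]1(O)CC[C@@H]2c1cccc(C)c1[C@@H]3Cn1cc(-c2ccc(C)cc2)nn1` is the next compound, not yet measured in this assay. Compound 3 differs from compound 2 in one place: 4-methylphenyl in place of pyridin-2-yl on an aromatic carbon. With both measured values at a limit there is no basis for a step in either direction, and no change beyond the scatter is expected.

The estimate is that compound 3 gives about 25000 nM in this assay, within 8000 nM to 80000 nM, most likely reported again as a limit.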

Compound 3, half-maximal inhibitory concentration: > 20000 nM
Compound 3: only a limit was reported; the forecaster's own chance of this, stated with the estimate: 75%; the middle value is on the limit's open side.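

Compound 3 also gives only a limit in this assay, > 20000 nM. With compound 2 likewise at a limit, no step between compound 2 and compound 3 can be read: the limit of > 20000 nM in this assay, at which 3 of the 3 values shown sit.

The compounds shown leave open how far each lies from that limit, and which change on the shared core, if any, would give a measurable value.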